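A few compounds are considered here, and "the series" means these few. Any claim that something is new, unique, unknown or untested is made for them only; others in the source may bear on it.

Three compounds share one core and carry a triazole that bears a substituted phenyl ring. Compound 1 `Cc1ccc(S(=O)(=O)Oc2ccc3c(c2C)[C@H](Cn2cc(-c4ccc(Cl)cc4)nn2)[C@@]24CC(=O)[C@@](C)(CC[C@@H]32)C4)cc1` and compound 2 `C=C1C[C@]23C[C@@]1(O)CC[C@H]2c1ccc(OS(=O)(=O)c2ccc(C)cc2)c(C)c1[C@@H]3Cn1cc(-c2ccc(C)cc2)nn1` both carry a sulfonate ester on the core where compound 3 `C=C1C(=O)[C@]23C[C@@]1(O)CC[C@H]2c1ccc(O)c(C)c1[C@@H]3Cn1cc(-c2ccc(F)cc2)nn1` has a free phenol, and compound 2 also lacks the ketone of compound 3. In a functional assay on HL-60 cells (Homo sapiens) for cytotoxicity, read by MTT assay, with a stated time of 4 days (on this read-out lower numbers stand for stronger inhibition and higher numbers for weaker inhibition), compound 1 gives > 20000 nM, which is a limit of the assay and not a number. Compound 2 likewise reaches only a limit in this assay, at > 20000 nM. Compound 3 is the only one of the three with a measured number in this assay, at 660 nM, so it is the sole point of reference; the other two readings are summed up by the limit of > 20000 nM in this assay, at which 2 of the 3 values shown sit.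

Compound 4 `C=C1C(=O)[C@]23C[C@@]1(O)CC[C@H]2c1ccc(O)c(C)c1[C@@H]3Cn1cc(-c2ccc(C)cc2)nn1` differs from compound 3 in one place: methyl in place of fluoro on an aromatic carbon. Going by the values given here, no step between measured compounds shows what such a swap does in this assay, and compound 2, which also carries a methyl on that ring, differs from compound 3 in other places too, so its limit cannot be read as a comparison. The step is therefore expected to stay within the usual scatter, as a 1.4-fold higher number from compound 3 to compound 4 (0.13 log units; within the scatter). Compound 4 is estimated at 900 nM, with a range from 300 nM to 3000 nM.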

Compound 4, half-maximal inhibitory concentration: 830 nM
For compound 4 the middle estimate is 1.1-fold (0.04 log units) above the measured one; the measured number falls inside the stated range.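

In this assay, going by these compounds alone, the swap of 4-fluorophenyl to 4-methylphenyl gives the first step between two compounds that differ in one place: a 1.3-fold higher number from compound 3 to compound 4 (0.10 log units; within the scatter). On an aromatic carbon para to a large group, then, fluoro and methyl cannot be told apart in this read-out, and the activity seen with compound 3 does not depend on the fluoro group alone. Nothing shown gives a reason for this result, since the only available observation concerns the compounds that reached the assay limit.

The compounds shown leave open whether this position would accept groups that differ more from fluoro and methyl, such as an amine, a carboxylic acid or a longer chain like butyl. They also leave open which feature separates compound 1 and compound 2 from compound 3 and compound 4, as compound 1 and compound 2 each differ from these two in more than one place, so neither the sulfonate ester nor any other single change can be singled out.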